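A Cyanomethoxy Variant Tested for Microsomal Half-Life

The source may hold more compounds than are shown below. What is called first, only, known or untested is meant among the compounds shown, and "the series" means these compounds.

Measured compounds and their half-lives:
Compound 1 `CC(C)[C@H]1C(O)=C(C2=NS(=O)(=O)c3ccccc32)C(=O)N1Cc1ccccc1` gives > 1 h in an in vitro ADME assay on microsomes from liver (Homo sapiens) for metabolic stability (a lower number here means that the compound disappears faster, a higher number that the compound lasts longer), which is a limit of the assay.
Compound 2 `CC(C)[C@H]1C(O)=C(C2=NS(=O)(=O)c3c(O)cccc32)C(=O)N1Cc1ccccc1` gives > 1 h in this assay, again a limit.
Compound 3 `CC(C)[C@H]1C(O)=C(C2=NS(=O)(=O)c3c(OCC(N)=O)cccc32)C(=O)N1Cc1ccccc1` gives > 1 h in this assay, also a limit.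

Compound 1 therefore stands at a limit rather than at a number in this assay, and the same holds for the two other measured compounds, so that the limit of > 1 h in this assay, at which 3 of the 3 values shown sit, describes the whole set. The unmeasured compound 4 `CC(C)[C@H]1C(O)=C(C2=NS(=O)(=O)c3c(OCC#N)cccc32)C(=O)N1Cc1ccccc1` differs from compound 1 by cyanomethoxy in place of hydrogen on an aromatic carbon.

Within the data shown here, three measured steps touch the same place on the shared core: a step that the two limits leave unreadable from compound 1 to compound 2, a step that the two limits leave unreadable from compound 1 to compound 3 and a step that the two limits leave unreadable from compound 2 to compound 3. None of them can be read as a size, since every value involved is a limit, so they show no movement that can be distinguished from the scatter. On this basis compound 4 is expected to remain at the limit of this assay as well, with a step estimated as a step that the limit leaves unreadable from compound 1 to compound 4. The estimate for compound 4 is 1.5 h, with a range from 0.7 h to 4 h.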

Compound 4, half-life: > 1 h
Compound 4 ended at the assay's limit (the forecaster's own chance of this, stated with the estimate: 75%); the middle value is on the limit's open side.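

Compound 4 sits at a limit in this assay, as do compound 1, compound 2 and compound 3, so no step among these compounds can be read as a size: the limit of > 1 h in this assay, at which 4 of the 4 values shown sit. Going by these compounds, how long each compound actually lasts, and whether cyanomethoxy in place of hydrogen changes that half-life, stays open.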